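A few compounds are considered here, and "the series" means these few. Any claim that something is new, unique, unknown or untested is made for them only; others in the source may bear on it.

The series shares one core carrying two hydroxyphenyl groups and a third aromatic group that varies. Compound 1 `Oc1cccc(-c2cc(-c3cccs3)cc(-c3ccccc3O)n2)c1` gives 9300 nM in a functional assay on DU-145 cells (Homo sapiens) for cytotoxicity, read by CCK-8 assay; a higher number here means a weaker inhibitor, a lower number a stronger inhibitor. Compound 2 `Oc1cccc(-c2cc(-c3ccoc3)cc(-c3ccccc3O)n2)c1` gives 2790 nM. Compound 3 `Oc1cccc(-c2cc(-c3ccccn3)cc(-c3ccccc3O)n2)c1` gives 17100 nM, the highest number of the three, although its gap to compound 1 lies within the scatter, whereas a 6.1-fold higher number from compound 2 to compound 3 (0.79 log units; beyond the scatter) lies beyond it. Compound 4 `Oc1cccc(-c2cc(-c3cccnc3)cc(-c3ccccc3O)n2)c1` is not yet measured; the change is pyridin-3-yl in place of pyridin-2-yl on an aromatic carbon. Within the data shown here, no measured step exchanges one pyridyl for another, so none bears directly on this change. Among the measured compounds shown here, the steps that do exist at this position, a 1.8-fold higher number from compound 1 to compound 3 (0.26 log units; within the scatter) and a 6.1-fold higher number from compound 2 to compound 3 (0.79 log units; beyond the scatter), mark pyridin-2-yl as the group with the highest number so far, but a shift of the ring nitrogen alone gives no ground for a step beyond the scatter in either direction. Compound 4 is therefore expected to give about 12000 nM, with a range from 4000 nM to 40000 nM. The expected step is a 1.4-fold lower number from compound 3 to compound 4 (0.15 log units; within the scatter), estimated to stay within the scatter.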

Compound 4, half-maximal inhibitory concentration: 5580 nM
Estimate against measurement, compound 4: 2.2-fold (0.33 log units) above; the measured number falls inside the stated range.
By their numbers in this assay, from the lowest: compounds 2, 4, 1 and 3 (each within the scatter of the next, the first and the last beyond it).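

In this assay the place of the ring nitrogen alone moves the number beyond the scatter (a 3.1-fold lower number from compound 3 to compound 4 (0.49 log units; beyond the scatter)), although pyridin-2-yl and pyridin-3-yl have the same heavy atoms and the same counts of donors and acceptors. Pyridin-3-yl cannot be told apart from either five-membered group (furan-3-yl: a 2.0-fold higher number from compound 2 to compound 4 (0.30 log units; within the scatter); thiophen-2-yl: a 1.7-fold lower number from compound 1 to compound 4 (0.22 log units; within the scatter)), so a pyridine ring at this carbon does not by itself go with the high number of compound 3. Nothing measured accounts for the shift between the two pyridyl groups. Open remains how pyridin-4-yl, or a phenyl ring carrying an amine or a carboxylic acid, would read at this carbon. From the compounds shown here alone, the 2-hydroxyphenyl and 3-hydroxyphenyl groups stand unchanged in all four compounds, so what their hydroxy groups contribute is also open.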